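This account rests on a few compounds, and the source may have more. Where it says the series, first, only, none or still open, it means among the compounds named here.

Among the compounds with values here, compound 2, `CC1(C)CCC(CN2CCN(c3ccc(C(=O)NS(=O)(=O)c4ccc(OC5CCOCC5)c([N+](=O)[O-])c4)c(Oc4cnc5[nH]ccc5c4)c3)CC2)=C(c2ccc(C(F)(F)F)cc2)C1`, is one of two compounds measured in an assay on isolated protein for displacement of a labelled ligand from Apoptosis regulator Bcl-2 (Homo sapiens), with a stated time of 15 min (a lower number here means a stronger inhibitor, a higher number a weaker inhibitor), where compound 2 gives 8.4 nM. That is the higher of the two numbers: compound 1, `CC1(C)CCC(CN2CCN(c3ccc(C(=O)NS(=O)(=O)c4ccc(OCC5CCOCC5)c([N+](=O)[O-])c4)c(Oc4cnc5[nH]ccc5c4)c3)CC2)=C(c2ccc(C(F)(F)F)cc2)C1`, gives 1 nM in this assay, and the change from compound 1 to compound 2 brought an 8.4-fold higher number from compound 1 to compound 2 (0.92 log units; beyond the scatter). Compound 3, `CC(Oc1ccc(S(=O)(=O)NC(=O)c2ccc(N3CCN(CC4=C(c5ccc(C(F)(F)F)cc5)CC(C)(C)CC4)CC3)cc2Oc2cnc3[nH]ccc3c2)cc1[N+](=O)[O-])C1CCOCC1`, has not been measured. It differs from compound 2 at one place: 1-(oxan-4-yl)ethyl in place of oxan-4-yl on an oxygen on an aromatic ring. Within the data shown here, the only measured step that bears on this change is the one from compound 1 to compound 2, in which the ring was drawn one carbon closer to the oxygen and the number rose beyond the scatter. Compound 3 again places a carbon between the oxygen and the ring, so it is expected to move back toward the number of compound 1, with a 4.2-fold lower number from compound 2 to compound 3 (0.62 log units; beyond the scatter) as the expected step. Compound 3 is therefore estimated at 2 nM in this assay, within a range from 0.7 nM to 6 nM.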

Compound 3, half-maximal inhibitory concentration: 9.2 nM
For compound 3 the middle estimate is 4.6-fold (0.66 log units) below the measured one; the whole stated range lies below it.
By their numbers in this assay, from the lowest: compound 1; then compounds 2 and 3 (each within the scatter of the next).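

In this assay, a methyl in place of hydrogen on the saturated chain carbon of the (oxan-4-yl)methyl group brings a 9.2-fold higher number from compound 1 to compound 3 (0.96 log units; beyond the scatter), so this one small addition costs about as much on the printed numbers as removing that chain carbon altogether did in an 8.4-fold higher number from compound 1 to compound 2 (0.92 log units; beyond the scatter). The 1-(oxan-4-yl)ethyl group of compound 3 keeps a carbon bound to the oxygen on the aromatic ring and to the saturated ring carbon, yet the comparison with oxan-4-yl gives a 1.1-fold higher number from compound 2 to compound 3 (0.04 log units; within the scatter), which shows that having that carbon present does not by itself return the number to that of compound 1. Nothing available here accounts for why the unsubstituted chain carbon of compound 1 stands apart from both of the other groups.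

The compounds shown leave open whether anything larger than a methyl on that chain carbon, such as an ethyl, would change the number any further. They also leave open how a longer chain, such as 2-(oxan-4-yl)ethyl, or a piperidine ring with its amine in place of the ring oxygen, would read in this assay.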